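Triazole series: one methoxy group removed from compound 3

The compounds below may be only part of what the source reports. "The series", "measured", "known", "first", "only" and "open" are said of these compounds alone.

Measured compounds and values in a functional assay on the whole organism (strain albino) for inhibition, with Rattus norvegicus as the target, read by paw edema, with a stated time of 4 h, at a dose of 0.28 mmol/kg by the oral route; on this read-out lower numbers stand for less inhibition and higher numbers for more inhibition at the one dose given (going by the name of the read-out):
compound 1, `C=CCn1c(SCC(=O)c2ccccc2)nnc1-c1ccc(OC)c(OC)c1`: 72%
compound 2, `C=CCn1c(SCC(=O)c2ccccc2)nnc1-c1ccc(OC)cc1`: 67%
compound 3, `CCn1c(SC/C(=N/O)c2ccccc2)nnc1-c1cc(OC)c(OC)c(OC)c1`: 79%

Compound 1 and compound 2 differ in one place, (hydrogen in place of methoxy on an aromatic carbon), and the step of a number 5 percentage points lower from compound 1 to compound 2 (within the scatter) is small. Compound 3 is built on another core; the difference between the two cores is not broken down here. Compound 3 and compound 1 lie within the scatter of each other, while compound 2 lies beyond the scatter below compound 3.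

Compound 4, `CCn1c(SC/C(=N/O)c2ccccc2)nnc1-c1ccc(OC)c(OC)c1`, is not yet measured. It differs from compound 3 by hydrogen in place of methoxy on an aromatic carbon. This is the same kind of change as that from compound 1 to compound 2; the place differs in that the carbon in compound 3 is also meta to a methoxy group, which is not so in compound 1.

For the measured compounds named here, with the earlier step as the only guide, the expected step from compound 3 to compound 4 is a number 5 percentage points lower from compound 3 to compound 4 (within the scatter), a small loss, because a number 5 percentage points lower from compound 1 to compound 2 (within the scatter) was small. Compound 4 is estimated at 74%, in the range 63% to 84%.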

Compound 4, a percentage reported as inhibition, in the whole organism at one dose (the size of the read-out at that dose, not a potency): 82%
Compound 4: the middle estimate sits 8 percentage points below what was measured, within the range that was stated.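

In this assay, hydrogen in place of methoxy on an aromatic carbon gives a number 3 percentage points higher from compound 3 to compound 4 (within the scatter), and the step does not stand apart from the one seen on the other core: the same change on two cores in this assay, a number 5 percentage points lower (within the scatter) from compound 1 to compound 2 and a number 3 percentage points higher (within the scatter) from compound 3 to compound 4, 8 percentage points apart, within the scatter of two such steps. On these two cores, then, the change stays within the scatter each time, and nothing marks it as behaving differently from one core to the other. This does not show that the two steps are equal or that the change has a direction, since each step is small and there are only two of them; the readings, taken at one dose and one time, also give the size of the effect and not a potency.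

The compounds shown leave open how a hydroxyl, a chlorine or an amine in place of the methoxy would read on either core. Also open is what the parts that separate the two cores contribute, as no pair shown differs in one of those parts alone.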